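This account rests on a few compounds, and the source may have more. Where it says the series, first, only, none or still open, it means among the compounds named here.

Compound 1 `COc1ccc(NC(=O)CSc2nc3c(N)ncnc3[nH]2)cc1OC` is the reference point here. In an assay on isolated protein for inhibition of Ectonucleotide pyrophosphatase/phosphodiesterase family member 1 (Homo sapiens) (a lower number here means a stronger inhibitor, a higher number a weaker inhibitor), compound 1 gives 5 nM, the lowest number among the two compounds measured. Within the data shown here, the only comparison available is compound 2 `COc1ccc(NC(=O)CSc2nc3cnccc3[nH]2)cc1OC`, which in this assay gives 44.2 nM; the gap between the two values is well beyond the usual scatter, so compound 1 is the stronger inhibitor of the pair. The two compounds differ at more than one place in the core, so nothing about any single change can be read from that gap.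

Compound 3 `COc1ccc(NC(=O)CSc2nc3c(N)nc(SC)nc3[nH]2)cc1OC` has not yet been measured. It differs from compound 1 in one place: methylsulfanyl in place of hydrogen on an aromatic carbon. Among the measured compounds shown here, no measured pair shows what this exchange does, so the expectation rests on the value of compound 1 alone. A small group added on the core is expected to shift the number only modestly, most likely by a step that stays within or only just beyond the scatter, in either direction. For compound 3 the estimated value in this assay is 8 nM, with a range from 2 nM to 30 nM. That estimate means a step of a 1.6-fold higher number from compound 1 to compound 3 (0.20 log units; within the scatter), expected rather than known.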

Compound 3, inhibition constant: 152 nM
Compound 3: the middle estimate sits 19-fold (1.28 log units) below what was measured, and the stated range ends below it.
By their numbers in this assay, from the lowest: compound 1; then compound 2; then compound 3.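

Putting methylsulfanyl in place of hydrogen on the aromatic carbon between two ring nitrogen atoms gives a 30-fold higher number from compound 1 to compound 3 (1.48 log units; beyond the scatter) in this assay. Among these compounds, this is the first single change that can be read in this small set, and it shows that this position is not a neutral place to add to the core: a group of just 2 heavy atoms, with no ring and no net charge, turns a strong inhibitor into a clearly weaker one. Nothing measured here says why the inhibition weakens so much at this carbon.

From the compounds shown here alone, with only hydrogen and methylsulfanyl compared on this carbon, it remains open whether any added group costs this much, or whether the loss is tied to this particular group, so a methyl group, a fluorine atom, an amine or a longer chain such as ethylsulfanyl could each give a different answer. Going by these compounds, it is also open whether methylsulfanyl would bring a step of similar size on a different core, since this exchange is seen only once, on the core of compound 1.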